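The compounds below may be only part of what the source reports. "The series", "measured", "known", "first", "only" and "open" are said of these compounds alone.

Measured so far in a functional assay on HT-29 cells (Homo sapiens) for cytotoxicity, read by XTT assay, with a stated time of 72 h; on this read-out lower numbers stand for stronger inhibition and higher numbers for weaker inhibition
- compound 1 `C=C1CC[C@H]2C(C)(C)CCC[C@]2(C)[C@H]1CC/C(C)=C/COc1c(-c2ccc(O)cc2)oc2cc(O)cc(O)c2c1=O` gives 30000 nM
- compound 2 `CC(C)=CCC/C=C(\C)Cc1c(O)cc(O)c2c(=O)c(O)c(-c3ccc(O)cc3)oc12` gives 30000 nM

Compound 1 stands level with compound 2 at the digits shown, and the two measured values show no gap within the series. Compound 3 `C=C1CC[C@H]2C(C)(C)CCC[C@]2(C)[C@H]1CC/C(C)=C/COc1c(-c2ccc(OC)cc2)oc2cc(O)cc(O)c2c1=O` carries one change from compound 1 (methyl in place of hydrogen on an oxygen on an aromatic ring): methyl in place of hydrogen on an oxygen on an aromatic ring, which reads as hydroxy to methoxy, or 4-hydroxyphenyl to 4-methoxyphenyl. Among the measured compounds shown here, no measured pair shows this change, so the data give no direct size for it in this assay and no direction can be argued from them. No step beyond the scatter is expected. The estimated step is no change at the digits printed from compound 1 to compound 3 (within the scatter) and is expected to stay within the scatter. For compound 3 the estimate is 30000 nM (expected range 12000 nM to 70000 nM).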

Compound 3, half-maximal inhibitory concentration: 32000 nM
Compound 3: middle estimate off by 1.1-fold (0.03 log units), on the low side; the range from low to high includes it.
By their numbers in this assay, from the lowest: compounds 1, 2 and 3 (each within the scatter of the next).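

In this assay, the series now has a direct measure of methyl in place of hydrogen on an oxygen on an aromatic ring, and the 4-hydroxyphenyl to 4-methoxyphenyl change gives a 1.1-fold higher number from compound 1 to compound 3 (0.03 log units; within the scatter). Among the compounds shown here, at this position, the hydrogen of the hydroxy group can therefore be replaced by methyl with the read-out staying within the scatter, which the earlier compounds could not show because they offered no measured pair for any single change. Nothing measured here offers an explanation for this result.

As far as these compounds go, whether a longer chain on the same oxygen, such as ethyl or benzyl, or an amine in place of the hydroxy group would also stay level with compound 1 remains open. This single pair also gives no size for methyl on the other hydroxy groups of the shared core.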